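The compounds below may be only part of what the source reports. "The series", "measured", "known", "first", "only" and "open" are said of these compounds alone.

Measured so far:
Compound 1 `CC(C)CCN(C)Cc1cn(C2CCCCC2OC(=O)c2ccccc2)nn1` gives 26%
Compound 2 `CN(Cc1cn(C2CCCCC2O)nn1)CC1CCCCC1` gives 47%

In an assay on nucleic acid for inhibition of Nucleic Acid, read by fluorescence, tested at 100 uM (on this read-out higher numbers stand for more inhibition at the one concentration tested (going by the name of the read-out) and lower numbers for less inhibition), compound 2 stands highest of the two numbers measured. Its nearest neighbour, compound 1, gives 26%, a gap that lies beyond the usual scatter of repeated runs. The two compounds differ in more than one place, so the gap cannot be tied to any single part of either structure.

Compound 3 `CN(Cc1cn(C2CCCCC2OC(=O)c2ccccc2)nn1)CC1CCCCC1` has not yet been measured. It differs from compound 2 in one place: benzoyl in place of hydrogen on an oxygen on a saturated carbon. Where compound 2 carries a free hydroxy group on the saturated ring, compound 3 carries a benzoyloxy group at the same position, and everything else is unchanged.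

Within the data shown here, with no single-change step between measured compounds to lean on, the expectation for this assay rests on the two measured numbers alone. A modest decrease is expected, with the step from compound 2 to compound 3 estimated at a number 12 percentage points lower from compound 2 to compound 3 (beyond the scatter), about the size of the usual scatter. Compound 3 is therefore expected to give roughly 35%, within a range of 15% to 55%.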

Compound 3, a percentage reported as inhibition, at one concentration (the size of the read-out at that concentration, not a potency): 32%
Beside the measured number, compound 3's estimate is 3 percentage points above it; the measured number falls inside the stated range.
By their numbers in this assay, from the lowest: compounds 1 and 3 (each within the scatter of the next); then compound 2.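

In this assay, among these compounds, the change of hydroxy to benzoyloxy, on an oxygen on a saturated carbon, gives the first step at this position that can be read on its own: a number 15 percentage points lower from compound 2 to compound 3 (beyond the scatter), so here the benzoyl group does not raise the number and the free hydroxy form stays ahead. With benzoyloxy held fixed, cyclohexyl in place of isobutyl on a saturated chain carbon bound to an amine nitrogen gives a number 6 percentage points higher from compound 1 to compound 3 (within the scatter), so in this setting the swap cannot be told apart from repeat scatter, and the earlier gap between compound 1 and compound 2 now appears to follow the change at the oxygen rather than this chain change. Nothing measured here explains why the benzoyl step goes the way it does.

Still open, going by these compounds, is whether this drop belongs to benzoyl in particular or would also follow a smaller group on the same oxygen, such as acetyl or methyl, or an amine in place of the hydroxy. The compounds shown also leave open whether cyclohexyl and isobutyl would still read alike with a free hydroxy on the saturated ring.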